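Shortening the hydroxycarbamoyl chain on a shared core

The source may hold more compounds than are shown below. What is called first, only, known or untested is meant among the compounds shown, and "the series" means these compounds.

Measured compounds:
compound 1, `CCOc1cc(C(C)(C)C)ccc1C1=NC(c2ccc(Cl)cc2)C(c2ccc(Cl)cc2)N1C(=O)N1CCN(CCCCCCCC(=O)NO)CC1` — 2010 nM
compound 2, `CCOc1cc(C(C)(C)C)ccc1C1=NC(c2ccc(Cl)cc2)C(c2ccc(Cl)cc2)N1C(=O)NCCCCCC(=O)Nc1ccccc1N` — 20300 nM
compound 3, `CCOc1cc(C(C)(C)C)ccc1C1=NC(c2ccc(Cl)cc2)C(c2ccc(Cl)cc2)N1C(=O)NCCCCCCCC(=O)Nc1ccccc1N` — 15200 nM

The three compounds share one core and differ only in the side chain carried on the urea nitrogen. In a functional assay on A549 cells (Homo sapiens) for antiproliferative activity, read by CCK-8 assay, with a stated time of 72 h (a lower number here means a stronger inhibitor, a higher number a weaker inhibitor), compound 1 gives 2010 nM, the lowest number of the three; compound 3 stands nearest to it and compound 2 furthest, both gaps beyond the scatter. Compounds 2 and 3 carry an (2-aminophenyl)carbamoyl end group rather than the hydroxycarbamoyl end group of compound 1, and the step of a 1.3-fold lower number from compound 2 to compound 3 (0.13 log units; within the scatter) shows that lengthening the chain there changed little.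

The unmeasured compound 4, `CCOc1cc(C(C)(C)C)ccc1C1=NC(c2ccc(Cl)cc2)C(c2ccc(Cl)cc2)N1C(=O)N1CCN(CCCCCC(=O)NO)CC1`, relates to compound 1 through (hydroxycarbamoyl in place of 2-(hydroxycarbamoyl)ethyl on a saturated chain carbon, five bonds along the chain from an amine nitrogen in a ring). Among the compounds with values here, no measured step concerns this exact change in the hydroxycarbamoyl series; the only chain-length step on record, a 1.3-fold lower number from compound 2 to compound 3 (0.13 log units; within the scatter), stays within the scatter, with the longer chain reading slightly lower. Going the other way, to a shorter chain, compound 4 is therefore expected to read slightly higher than compound 1, by about a 1.4-fold higher number from compound 1 to compound 4 (0.14 log units; within the scatter), a step that may still fall within the scatter. Compound 4 is estimated at 2800 nM, with a range from 1400 nM to 6000 nM.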

Compound 4, half-maximal inhibitory concentration: 2910 nM
Beside the measured number, compound 4's estimate is 1.0-fold (0.02 log units) below it; measured number inside the range.
By their numbers in this assay, from the lowest: compounds 1 and 4 (each within the scatter of the next); then compounds 3 and 2 (each within the scatter of the next).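

In this assay, the step of a 1.4-fold higher number from compound 1 to compound 4 (0.16 log units; within the scatter) is the only chain-length step shown in the hydroxycarbamoyl series, and it lies within the scatter, so hydroxycarbamoyl in place of 2-(hydroxycarbamoyl)ethyl, on a saturated chain carbon five bonds along the chain from an amine nitrogen in a ring, leaves no difference that these numbers can resolve. The earlier step of a 1.3-fold lower number from compound 2 to compound 3 (0.13 log units; within the scatter) is also within the scatter, so neither of the two chain-length pairs shown, one ending in hydroxycarbamoyl and one in (2-aminophenyl)carbamoyl, gives a difference beyond the scatter. Nothing available alongside these numbers bears on the reason for this result.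

The compounds shown leave open how far this tolerance extends: whether a still shorter chain such as (hydroxycarbamoyl)methyl, a much longer chain, or a carboxylic acid in place of the hydroxycarbamoyl end would read alike. They also leave unresolved how much of the gap between compound 1 and compound 3 belongs to the end group and how much to the amine ring, since those two compounds differ in more than one place.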